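Ether side-chain variation on the shared naphthoquinone-free core

A few compounds are considered here, and "the series" means these few. Any claim that something is new, unique, unknown or untested is made for them only; others in the source may bear on it.

Measured so far in a functional assay on DU-145 cells (Homo sapiens) for cytotoxicity, read by MTT assay; a lower number here means a stronger inhibitor, a higher number a weaker inhibitor:
compound 1 `CCCC(CC(=O)O[C@H](CC=C(C)C)C1=CC(=O)c2c(O)ccc(O)c2C1=O)OC(C)=O`: 55700 nM
compound 2 `CC(C)=CC[C@@H](OCC(C)O)C1=CC(=O)c2c(O)ccc(O)c2C1=O`: 16100 nM
compound 3 `CC(C)=CC[C@@H](OC(=O)CC(C)(O)c1ccccc1)C1=CC(=O)c2c(O)ccc(O)c2C1=O`: a limit, > 100000 nM

Compound 2 gives the lowest of the two numbers in this assay; compound 1 sits higher, by a gap beyond the usual scatter. For compound 3 only a limit is recorded, so its value cannot be placed in order with the others beyond saying that it is the weakest of the set. Among the compounds with values here, the one measured step with a single change, an at least 1.7-fold higher number from compound 1 to compound 3 (0.25 log units; that floor lies within the scatter), is only a floor, since one of the three values sits at the limit of > 100000 nM in this assay, at which 1 of the 3 values shown sits; it concerns the ester chain and not the ether, so it does not bear directly on the step to compound 4.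

Compound 4 `CCC(CO[C@H](CC=C(C)C)C1=CC(=O)c2c(O)ccc(O)c2C1=O)OC` differs from compound 2 in one place: 1-methoxypropyl in place of 1-hydroxyethyl on a saturated chain carbon bound to an oxygen on a saturated carbon. Within the data shown here, no measured pair shows the loss of the hydroxyl on this ether chain, so there is no basis for expecting a step in either direction beyond the scatter; the expected change is therefore a 1.2-fold higher number from compound 2 to compound 4 (0.09 log units; within the scatter). In this assay compound 4 is estimated at 20000 nM, within a range from 7000 nM to 60000 nM.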

Compound 4, half-maximal inhibitory concentration: 45700 nM
Beside the measured number, compound 4's estimate is 2.3-fold (0.36 log units) below it; the measured number falls inside the stated range.
By their numbers in this assay, from the lowest: compound 2; then compounds 4 and 1 (each within the scatter of the next). At a limit, above all of these: compound 3.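

In this assay the change from 1-hydroxyethyl to 1-methoxypropyl gives a 2.8-fold higher number from compound 2 to compound 4 (0.45 log units; beyond the scatter) as the only step shown at this position, on a saturated chain carbon bound to an oxygen on a saturated carbon, and unlike the floor on the ester chain it is a step between two numbers. The ether chain at this position is therefore not indifferent to substitution, and this modest change moves the read-out past the usual scatter toward a weaker inhibitor. The change bundles two differences, going from 1 hydrogen-bond donor to 0 and from 3 heavy atoms to 5, and nothing measured on hand speaks to the reason for the step.

Which of the two differences carries the step stays open, since only 1-methoxyethyl or 1-hydroxypropyl at this place would separate the capping of the hydroxyl from the added chain length. Going by these compounds, how an amine, a carboxylic acid or a longer chain bearing a free hydroxyl would read at the same place is also open.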